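Replacing Chlorine With Methylsulfinyl on a Weak Inhibitor

The source may hold more compounds than are shown below. What is called first, only, known or untested is meant among the compounds shown, and "the series" means these compounds.

Compound 3 `NC1=C(Cl)C(=O)c2ncccc2C1=O` was tested in a functional assay on cells (Neutrophil, Homo sapiens) for inhibition, read by WST assay, with a stated time of 20 min; on this read-out lower numbers stand for stronger inhibition and higher numbers for weaker inhibition. For compound 3 the result is only a limit of the assay, > 200000 nM, and not a number (the limit of > 200000 nM in this assay, at which 1 of the 3 values shown sits). Two relatives give numbers: compound 1 `CNC1=C(Cl)C(=O)c2ncccc2C1=O` gives 78900 nM, and compound 2 `O=C1C(NC(c2ccccc2)c2ccccc2)=C(Cl)C(=O)c2ncccc21` gives 33900 nM. Going by the values given here, the one measured step, an at least 2.5-fold higher number from compound 1 to compound 3 (0.40 log units; beyond the scatter), concerns the amine nitrogen, not the chlorine. Compound 4 `C[S+]([O-])C1=C(N)C(=O)c2cccnc2C1=O` differs from compound 3 by a group of 3 heavy atoms (1 carbon, 1 oxygen, 1 sulfur; no ring) in place of one chlorine atom, on a double-bonded ring carbon. Among the compounds with values here, no measured step bears on this change, so no shift beyond the scatter is expected. Because compound 3 gives only the limit > 200000 nM, compound 4 is expected to remain near it. The estimated value for compound 4 is 200000 nM, between 80000 nM and 500000 nM, an expected step of a number no higher from compound 3 to compound 4 (the limit leaves the size open).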

Compound 4, half-maximal inhibitory concentration: > 200000 nM
Compound 4 ended at the assay's limit; the forecaster's own chance of this, stated with the estimate: 70%; the middle value lies on the limit itself.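

Compound 3 and compound 4 both sit at a limit of the assay rather than at a number, so no step between them can be read: the limit of > 200000 nM in this assay, at which 2 of the 4 values shown sit.

On these data alone, whether swapping the chlorine for this sulfur-bearing group changes inhibition at all stays open.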